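The source may hold more compounds than are shown below. What is called first, only, known or untested is meant among the compounds shown, and "the series" means these compounds.

Two members of the series have been measured in an assay on membranes from HEK293 cells for displacement of a labelled ligand from adenosine receptor A2b (Homo sapiens), read by scintillation counting, with a stated time of 30 min, tested at 1 uM; on this read-out higher numbers stand for more inhibition at the one concentration tested (going by the name of the read-out) and lower numbers for less inhibition. Compound 1 `CC1=C(C(N)=O)C(c2ccsc2)NC(=O)N1` gives 1% in that assay, and compound 2 `CCSC(=O)C1=C(C)NC(=O)NC1c1ccsc1` gives 17%. Among the compounds with values here, the single measured step, a number 16 percentage points higher from compound 1 to compound 2 (beyond the scatter), is the only comparison available, and on it compound 2 stands highest of the two numbers, with compound 1 as its nearest neighbour.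

Compound 3 `CC1=C(C(=O)SC(C)C)C(c2ccsc2)NC(=O)N1` is not yet measured in this assay. It differs from compound 2 by methyl in place of hydrogen on a saturated chain carbon bound to a saturated chain carbon and a sulfur. Within the data shown here, no measured step touches this place: the one step known concerns a different position on the shared core, so nothing in the data speaks for or against a change in the read-out here. The expectation for compound 3 is therefore built on compound 2 alone, a step of a number 3 percentage points higher from compound 2 to compound 3 (within the scatter) that is not expected to pass beyond the scatter. Compound 3 is estimated at 20%, with a range from 5% to 40%.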

Compound 3, a percentage reported as inhibition, at one concentration (the size of the read-out at that concentration, not a potency): 14%
Compound 3: middle estimate off by 6 percentage points, on the high side, within the range that was stated.
By their numbers in this assay, from the lowest: compound 1; then compounds 3 and 2 (each within the scatter of the next).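

In this assay the change shows a number 3 percentage points lower from compound 2 to compound 3 (within the scatter) for methyl in place of hydrogen on a saturated chain carbon bound to a saturated chain carbon and a sulfur, so going from ethylsulfanyl to isopropylsulfanyl gives no readable change at this position. Set against the amino group of compound 1, isopropylsulfanyl gives a number 13 percentage points higher from compound 1 to compound 3 (beyond the scatter) on the same carbonyl carbon, so both sulfanyl groups shown stand apart from amino by a modest step. The data available give no explanation for either step.

Still open, going by these compounds, is whether a longer chain such as butyl, or a cyclopentyl group, on the sulfur stays in the same range. Also open, on these data alone, is whether an ethoxy or a methylamino group on the carbonyl carbon reads like the sulfanyl groups or like amino.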